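This account rests on a few compounds, and the source may have more. Where it says the series, first, only, none or still open, it means among the compounds named here.

In an in vitro ADME assay on microsomes from liver (Homo sapiens) for metabolic stability (a higher number here means faster removal of the compound, a lower number slower removal), compound 1 (`O=C(COCc1ccccn1)N1CCN(c2ccc(Cl)cc2Cl)CC1`) gives 94 mL.min-1.g-1 and compound 2 (`O=C(COCc1cccnc1)N1CCN(c2ccc(Cl)cc2Cl)CC1`) gives 210 mL.min-1.g-1 as the higher of the two numbers, so compound 2 stands at the top of the short range measured so far. The next structure, compound 3 (`O=C(COCc1cnccn1)N1CCN(c2ccc(Cl)cc2Cl)CC1`), differs from compound 2 (pyrazin-2-yl in place of pyridin-3-yl on a saturated chain carbon bound to an oxygen on a saturated carbon), with pyrazin-2-yl in place of pyridin-3-yl on a saturated chain carbon bound to an oxygen on a saturated carbon. Going by the values given here, one measured step bears on this place (a 2.2-fold higher number from compound 1 to compound 2 (0.35 log units; beyond the scatter)), a modest one beyond the scatter, with pyridin-3-yl in place of pyridin-2-yl. Among the compounds with values here, no measured compound carries pyrazin-2-yl, so the direction rests on little evidence. The only other measured ring, in compound 1 (94 mL.min-1.g-1), gives the lower number, so a modest step down in this assay is expected, of about the size of that one measured step. The expected step (a 2.2-fold lower number from compound 2 to compound 3 (0.34 log units; beyond the scatter)) is uncertain in size. For compound 3 the estimate is 95 mL.min-1.g-1 (range 45 mL.min-1.g-1 to 190 mL.min-1.g-1).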

Compound 3, intrinsic clearance in microsomes: 4 mL.min-1.g-1
Beside the measured number, compound 3's estimate is 24-fold (1.38 log units) above it; the whole stated range lies above it.
By their numbers in this assay, from the lowest: compound 3; then compound 1; then compound 2.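

Notes on the ring on a saturated chain carbon bound to an oxygen on a saturated carbon: in this assay this place responds far more strongly than the pyridin-2-yl and pyridin-3-yl pair indicated, with a modest earlier step (a 2.2-fold higher number from compound 1 to compound 2 (0.35 log units; beyond the scatter)) against a large one from the more clearing pyridine (a 53-fold lower number from compound 2 to compound 3 (1.72 log units; beyond the scatter)). The drop does not depend on which pyridine serves as the reference, since the other comparison is also large (a 24-fold lower number from compound 1 to compound 3 (1.37 log units; beyond the scatter)), so among these three compounds the ring with 2 hetero atoms stands apart from both rings with 1 hetero atom. Nothing measured here accounts for the size of this drop.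

Open, from the compounds shown here alone, is whether the low number belongs to pyrazin-2-yl specifically or extends to other six-membered aromatic rings with 2 hetero atoms, such as pyrimidin-5-yl or pyridazin-3-yl, and where a plain phenyl ring would fall relative to these three compounds. Also open, going by these compounds, is whether the same ring change holds its effect with a longer chain in place of the methoxy link, or with an amine on the ring of pyrazin-2-yl.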